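Trading Trifluoromethyl for Fluoro on an Aryl Urea

The source may report more compounds than this note shows. Statements on the series, on what has been measured and on what is new or still open speak of the compounds shown alone.

Of the compounds shown here, three sharing one core have been measured in a functional assay on RPMI-8226 cells (Homo sapiens) for inhibition; on this read-out higher numbers stand for weaker inhibition and lower numbers for stronger inhibition. Compound 1 `CCOC(=O)c1ccc(NC(=O)N2CC2C#N)cc1` carries an ethoxycarbonyl group on its aromatic ring, and in this assay compound 1 gives 3000 nM. Compound 2 `N#CC1CN1C(=O)Nc1ccc(S(N)(=O)=O)cc1` carries a sulfamoyl group in the same place; in this assay compound 2 gives > 38000 nM, which is a limit of the measurement rather than a number. The value of compound 2 is the limit (the limit of > 38000 nM in this assay, at which 1 of the 3 values shown sits). Compound 3 `N#CC1CN1C(=O)Nc1ccc(C(F)(F)F)cc1` carries trifluoromethyl there, and in this assay compound 3 gives 8200 nM. Among the two plain numbers compound 3 stands highest, with compound 1 nearest, the step being a 2.7-fold higher number from compound 1 to compound 3 (0.44 log units; beyond the scatter). The other measured step involving compound 3 is an at least 4.6-fold lower number from compound 2 to compound 3 (0.66 log units; beyond the scatter).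

Compound 4 `N#CC1CN1C(=O)Nc1ccc(F)cc1` has not yet been measured. It differs from compound 3 in one place: fluoro in place of trifluoromethyl on an aromatic carbon. Among the measured compounds shown here, no measured step swaps trifluoromethyl for fluoro. The three steps among compounds 1, 2 and 3 show how far a change in this place can move the number: the largest of them is an at least 12-fold higher number from compound 1 to compound 2 (1.10 log units; beyond the scatter), and the other two are modest. A modest step, in either direction, is therefore expected; the estimate here leans toward slightly weaker inhibition, expected as a 1.5-fold higher number from compound 3 to compound 4 (0.17 log units; within the scatter). In this assay compound 4 is expected to give about 12000 nM, most likely between 3000 nM and 40000 nM.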

Compound 4, half-maximal inhibitory concentration: 5000 nM
Compound 4: middle estimate off by 2.4-fold (0.38 log units), on the high side; the range from low to high includes it.
By their numbers in this assay, from the lowest: compounds 1, 4 and 3 (each within the scatter of the next, the first and the last beyond it). At a limit, above all of these: compound 2.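

Replacing the 4 heavy atoms of trifluoromethyl with the single atom of fluoro barely registers in this assay, giving a 1.6-fold lower number from compound 3 to compound 4 (0.21 log units; within the scatter), so a much smaller group on this aromatic carbon costs nothing that can be told from the scatter. Fluoro also cannot be separated from ethoxycarbonyl, with a 1.7-fold higher number from compound 1 to compound 4 (0.22 log units; within the scatter), which places compound 4 within the scatter of both compound 1 and compound 3, even though those two differ from each other beyond it. Among the four groups, only sulfamoyl stands clearly apart, with an at least 7.6-fold lower number from compound 2 to compound 4 (0.88 log units; beyond the scatter), and the value behind that step is a limit of the measurement, not a number: the limit of > 38000 nM in this assay, at which 1 of the 4 values shown sits.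

What the compounds shown leave open is whether an amine or a carboxylic acid on this aromatic carbon would fall with sulfamoyl or with the other three groups, and whether a longer chain than ethoxycarbonyl would keep the number in the same range. They also cannot say how far sulfamoyl really lies from the rest, or why it behaves differently, and four groups at one position are too few to support a general rule.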